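Solubility notes on the indole-amide series: compound 1 to 4

This account rests on a few compounds, and the source may have more. Where it says the series, first, only, none or still open, it means among the compounds named here.

Compound 1 `COc1ccc2[nH]c(C(=O)N3CC(=O)N(Cc4ccccc4)[C@@H](COc4ccccc4)C3)cc2c1` gives 12200 nM in a physicochemical assay for solubility, read by spectrophotometry, in phosphate buffer, with a stated time of 2 h, at pH 7.4 (on this read-out higher numbers stand for higher solubility and lower numbers for lower solubility), the lowest of the three measured values. Compound 2 `COc1ccc2[nH]c(C(=O)N3CC(=O)N(Cc4cccc(OC(F)F)c4)[C@@H](CN4CCC(C#N)CC4)C3)cc2c1` gives 27900 nM and compound 3 `COc1ccc2[nH]c(C(=O)N3CC(=O)N(Cc4cccc(OC(F)F)c4)[C@@H](CN4CCN(C5CC5)CC4)C3)cc2c1` gives 99600 nM; both carry a nitrogen ring on the saturated chain carbon and both sit higher than compound 1, though they also differ from it elsewhere. Compound 4 `COc1ccc2[nH]c(C(=O)N3CC(=O)N(Cc4ccccc4)[C@@H](CN4CC5CCCC5C4)C3)cc2c1` differs from compound 1 by a group of 8 heavy atoms (7 carbon, 1 nitrogen; one five-membered non-aromatic ring of carbon only, one five-membered non-aromatic ring with 1 hetero atom) in place of a group of 7 heavy atoms (6 carbon, 1 oxygen; one six-membered aromatic ring of carbon only), on a saturated chain carbon bound to a saturated ring carbon. Going by the values given here, the only single-point step, a 3.6-fold higher number from compound 2 to compound 3 (0.55 log units; beyond the scatter), concerns a swap between two nitrogen rings rather than an ether for a nitrogen ring, so it bears on the change only loosely. A step of a 2.5-fold higher number from compound 1 to compound 4 (0.39 log units; beyond the scatter) is expected, upward. Compound 4 is estimated at 30000 nM, with a range from 10000 nM to 90000 nM.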

Compound 4, solubility: 20700 nM
Compound 4: middle estimate off by 1.4-fold (0.16 log units), on the high side; the range from low to high includes it.
By their numbers in this assay, from the lowest: compounds 1, 4 and 2 (each within the scatter of the next, the first and the last beyond it); then compound 3.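

In this assay, the swap of phenoxy for the group of 8 heavy atoms on a saturated chain carbon bound to a saturated ring carbon reads as a 1.7-fold higher number from compound 1 to compound 4 (0.23 log units; within the scatter). At this position, then, a nitrogen-bearing pair of five-membered non-aromatic rings and an aromatic ether stand level on this read-out. No supporting data bear on this result.

Still open, from the compounds shown here alone, is how a morpholine ring or a carboxylic acid on the same carbon would read. Also open, going by these compounds, is whether the higher value of compound 3 would persist on a core carrying the unsubstituted benzyl of compound 1.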